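This account rests on a few compounds, and the source may have more. Where it says the series, first, only, none or still open, it means among the compounds named here.

The measured compounds:

Compound 1, `O=C(Nc1cccc(-c2oc3cc(-c4ccc(F)cc4)ccc3c(=O)c2O)c1)c1ccc(Cl)cc1`: 4030 nM
Compound 2, `O=C(Nc1cccc(-c2oc3cc(-c4ccc(F)cc4)ccc3c(=O)c2O)c1)c1cccc(F)c1`: 6590 nM
Compound 3, `O=C(Nc1cccc(-c2oc3cc(-c4ccc(F)cc4)ccc3c(=O)c2O)c1)c1ccc([N+](=O)[O-])cc1`: 5640 nM

All three share one core and differ only in the group on the carbonyl carbon of the amide. In a functional assay on HCC1937 cells (Homo sapiens) for antiproliferative activity, read by CCK-8 assay, with a stated time of 72 h (on this read-out lower numbers stand for stronger inhibition and higher numbers for weaker inhibition), compound 3 gives the second highest of the three numbers. Its neighbours sit close: a 1.2-fold lower number from compound 2 to compound 3 (0.07 log units; within the scatter) and a 1.4-fold higher number from compound 1 to compound 3 (0.15 log units; within the scatter). Compound 2 and compound 1 are likewise close, a 1.6-fold higher number from compound 1 to compound 2 (0.21 log units; within the scatter). None of these three steps reaches beyond the scatter, so the numbers give no ground to rank the compounds against each other.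

Compound 4, `O=C(Nc1cccc(-c2oc3cc(-c4ccc(F)cc4)ccc3c(=O)c2O)c1)c1ccc(-c2ccccc2)cc1`, carries the change (phenyl in place of nitro on an aromatic carbon); read one bond further out, a 4-nitrophenyl becomes a 4-phenylphenyl. Among the measured compounds shown here, the steps that bear on it are those that also swap the group on the benzoyl ring, namely the three steps above, and each was within the scatter. On that basis the step from compound 3 to compound 4 in this assay is expected to stay within the scatter as well, with no direction to be read from it. The expected step is a 1.1-fold lower number from compound 3 to compound 4 (0.05 log units; within the scatter). Compound 4 is therefore estimated at 5000 nM, within a range from 2000 nM to 15000 nM.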

Compound 4, half-maximal inhibitory concentration: 44100 nM
The estimate for compound 4 lay 8.8-fold (0.95 log units) below the measured number, and the stated range ends below it.
By their numbers in this assay, from the lowest: compounds 1, 3 and 2 (each within the scatter of the next); then compound 4.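

In this assay, the swaps among chloro, nitro and 3-fluorophenyl left the numbers within the scatter, whereas 4-phenylphenyl moves the number beyond it: a 7.8-fold higher number from compound 3 to compound 4 (0.89 log units; beyond the scatter), with a 6.7-fold higher number from compound 2 to compound 4 (0.83 log units; beyond the scatter) and an 11-fold higher number from compound 1 to compound 4 (1.04 log units; beyond the scatter). All three steps run towards weaker inhibition, so this position on the benzoyl ring is not indifferent to its substituent, and a phenyl on this aromatic carbon is the one change shown that separates a compound from the others. Nothing at hand bears on why the number rises at this step.

The compounds shown leave open whether the loss belongs to an aromatic ring at this place or to any group of similar size, which a cyclohexyl or a pyridyl group on the same carbon could begin to separate. They also leave open whether a smaller group such as methoxy or an amine would stay level with compound 1, compound 2 and compound 3, or would move the number in either direction.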